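The source may hold more compounds than are shown below. What is called first, only, known or untested is meant among the compounds shown, and "the series" means these compounds.

Compound 1 `COc1ccc(F)cc1CNCCCNc1ccnc2cc(Oc3ccc(C(C)(C)C)cc3)ccc12` gives 9.28 in a physicochemical assay for acid dissociation.
Compound 2 `COc1ccc(F)cc1CNCCCNc1ccnc2cc(Oc3ccc(F)cc3)ccc12` gives 9.28 in this assay.
Compound 3 `COc1ccc(F)cc1CNCCCNc1ccnc2cc(Cc3cccc(C(F)(F)F)c3)ccc12` gives 9.47 in this assay.

These three compounds share one core and differ only in the group carried on one aromatic carbon of that core. Compound 3 differs from compound 1 by a number 0.19 log units higher from compound 1 to compound 3 (within the scatter) and from compound 2 by a number 0.19 log units higher from compound 2 to compound 3 (within the scatter); both steps lie within the scatter, so the three numbers cannot be told apart. The step of no change at the digits printed from compound 1 to compound 2 (within the scatter) likewise shows no change.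

Compound 4 `COc1ccc(F)cc1CNCCCNc1ccnc2cc(Oc3ccccc3OC)ccc12` is the next compound and has not yet been measured. The change from compound 3 is this: 2-methoxyphenoxy in place of 3-(trifluoromethyl)benzyl on an aromatic carbon. All three measured steps bear on it, since each of them also swaps the group on this same aromatic carbon, and none of them moved the number beyond the scatter. Two acceptor atoms enter with the new group, which the earlier swaps did not bring in, so the record does not cover this exactly.

Even so, the expectation for compound 4 is a step of about a number 0.12 log units lower from compound 3 to compound 4 (within the scatter), that is, nothing beyond the scatter. The estimate for compound 4 is 9.35, with a range from 9 to 9.7.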

Compound 4, acid dissociation constant: 9.28
Beside the measured number, compound 4's estimate is 0.07 log units above it, within the range that was stated.
By their numbers in this assay, from the lowest: compounds 1, 2, 4 and 3 (each within the scatter of the next).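

Placing 2-methoxyphenoxy on this aromatic carbon gives, in this assay, a number 0.19 log units lower from compound 3 to compound 4 (within the scatter) and so shows that a group counted with hydrogen-bond acceptors, where 3-(trifluoromethyl)benzyl has none, still does not separate itself from the earlier compounds. With the oxygen kept and only the group on it swapped, the reading is no change at the digits printed from compound 2 to compound 4 (within the scatter) and no change at the digits printed from compound 1 to compound 4 (within the scatter), so 2-methoxyphenyl on that oxygen cannot be told apart from 4-fluorophenyl or 4-(tert-butyl)phenyl, and all four compounds now read as one level at this position. No separate measurement is available to account for this flat result.

The compounds shown leave open whether a group of a different kind on this aromatic carbon, such as an amine or a carboxylic acid, would move the number beyond the scatter. They also leave open whether a change elsewhere on the shared core, such as a longer chain, would do so, since every compound here differs from the others only at this one place.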